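The compounds below may be only part of what the source reports. "The series", "measured", "known", "first", "only" and "open" are said of these compounds alone.

Measured so far:
compound 1 `O=c1[nH]cnc2c1c(-c1cccs1)cn2[C@@H]1O[C@H](CO)[C@@H](O)[C@H]1O` — > 20000 nM
compound 2 `Nc1nc2c(c(-c3cccs3)cn2[C@@H]2O[C@H](CO)[C@@H](O)[C@H]2O)c(=O)[nH]1` — > 20000 nM

In a functional assay on HepG2 cells (Homo sapiens) for antiproliferative activity, read by XTT assay, with a stated time of 72 h (a lower number here means a stronger inhibitor, a higher number a weaker inhibitor), compound 1 gives > 20000 nM, which is a limit of the assay and not a number. Compound 2 gives > 20000 nM in this assay, also a limit. Going by the values given here, the only step between measured compounds, a step that the two limits leave unreadable from compound 1 to compound 2, is unreadable because both values sit at the limit of > 20000 nM in this assay, at which 2 of the 2 values shown sit. So compound 1 stands only at a limit, with no numerical value to anchor it.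

Compound 3 `O=c1[nH]cnc2c1c(-c1cc3ccccc3o1)cn2[C@@H]1O[C@H](CO)[C@@H](O)[C@H]1O` has not yet been measured in this assay. It differs from compound 1 in one place: 1-benzofuran-2-yl in place of thiophen-2-yl on an aromatic carbon. Among the compounds with values here, no measured step bears on this change, so nothing points to a direction beyond the scatter. Compound 3 is therefore expected to remain weak, at about 30000 nM, within 8000 nM to 100000 nM. The step that the limit leaves unreadable from compound 1 to compound 3 is expected to be small.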

Compound 3, half-maximal inhibitory concentration: > 20000 nM
Compound 3 ended at the assay's limit; the forecaster's own chance of this, stated with the estimate: 70%; the middle value is on the limit's open side.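

Going by these compounds alone, compound 3 also stops at a limit of the assay and not at a number, so no step between compound 1, compound 2 and compound 3 can be read, because all the values sit at one limit: the limit of > 20000 nM in this assay, at which 3 of the 3 values shown sit.

In this assay the compounds shown leave open whether any group on the shared core gives a readable value.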